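This account rests on a few compounds, and the source may have more. Where it says the series, first, only, none or still open, it means among the compounds named here.

Measured so far:
- compound 1 `ClCc1cccc(Cn2cnc3ncnc(Cl)c32)c1` — > 100000 nM
- compound 2 `ClCc1ccc(Cn2cnc3c(Cl)nc(Cl)nc32)cc1` — 66100 nM

In a functional assay on OVCAR-5 cells (Homo sapiens) for cytotoxicity, read by sulforhodamine B assay, with a stated time of 48 h (on this read-out lower numbers stand for higher toxicity in this test and higher numbers for lower toxicity in this test), compound 1 reaches only the limit of the assay, > 100000 nM, and no number is known for it; the series therefore has one real value, (the limit of > 100000 nM in this assay, at which 1 of the 2 values shown sits). In this assay compound 2 gives 66100 nM. Among the measured compounds shown here, no step between measured compounds can be drawn, as the pair differ in more than one place.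

Compound 3 `ClCc1cccc(Cn2cnc3nc(Cl)nc(Cl)c32)c1` is not yet measured. It differs from compound 1 by chloro in place of hydrogen on an aromatic carbon, on an aromatic carbon of a six-membered aromatic ring with two nitrogen, between two ring nitrogen atoms, meta to a chloro group. For the step from compound 1 to compound 3 the expectation is a small gain in toxicity at most, possibly none beyond the scatter, since compound 1 sits at a limit and a step size cannot be fixed. Compound 3 is expected at 60000 nM, with a range of 20000 nM to 150000 nM, meaning an expected step of an at least 1.6-fold lower number from compound 1 to compound 3 (0.22 log units; that floor lies within the scatter); weak toxicity is estimated, with a fair chance that only a limit is reported again.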

Compound 3, concentration lethal to 50% of the cells: 6300 nM
For compound 3 the middle estimate is 9.5-fold (0.98 log units) above the measured one; the whole stated range lies above it.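

In this assay, chloro in place of hydrogen on an aromatic carbon, between two ring nitrogen atoms, brings an at least 15-fold lower number from compound 1 to compound 3 (1.20 log units; beyond the scatter), the first sign in the series that this position of the shared core affects toxicity in this test. Compound 1 gives > 100000 nM, which is a limit of the assay. The step is therefore a floor, and its true size is unknown: the limit of > 100000 nM in this assay, at which 1 of the 3 values shown sits.

On these data alone, whether the gain is specific to chloro stays open, and an amine, a methoxy group or fluoro at the same position would test this. As far as these compounds go, the part played by the chloromethyl group also stays open, and a hydroxymethyl group in its place, on the core of compound 3, would address it.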